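The compounds below may be only part of what the source reports. "The series", "measured", "known", "first", "only" and "open" are said of these compounds alone.

Compound 1 `COc1cc(-n2cnc3ccc(-c4cccc(C)c4C)cc32)cc(OC)c1OC` carries a 2,3-dimethylphenyl group on an aromatic carbon of the shared core; in a functional assay on A549 cells (Homo sapiens) for antiproliferative activity, read by MTT assay, with a stated time of 72 h (on this read-out lower numbers stand for stronger inhibition and higher numbers for weaker inhibition), compound 1 gives 9250 nM. Compound 2 `COc1cc(-n2cnc3ccc(-c4ccc(Cl)cc4)cc32)cc(OC)c1OC` carries 4-chlorophenyl in place of 2,3-dimethylphenyl on an aromatic carbon. For compound 2 this assay returns only a limit, > 10000 nM, not a number. The step of an at least 1.0-fold higher number from compound 1 to compound 2 (0.03 log units; that floor lies within the scatter) is thus a floor set by the limit of > 10000 nM in this assay, at which 1 of the 2 values shown sits. Compound 2 therefore stands at the weak edge of what this assay can report, with compound 1 only slightly inside it. Compound 3 `COc1cc(-n2cnc3ccc(-c4ccc(F)cc4)cc32)cc(OC)c1OC` differs from compound 2 by fluoro in place of chloro on an aromatic carbon. Going by the values given here, the only measured step, an at least 1.0-fold higher number from compound 1 to compound 2 (0.03 log units; that floor lies within the scatter), concerns a different group and ends at the limit, so it gives no direction for this change. The expected step that the limit leaves unreadable from compound 2 to compound 3 is none beyond the scatter. Compound 3 is expected to give about 12000 nM in this assay, in the range 5000 nM to 30000 nM, and quite possibly again only a limit.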

Compound 3, half-maximal inhibitory concentration: 6740 nM
Compound 3: the middle estimate sits 1.8-fold (0.25 log units) above what was measured; the measured number falls inside the stated range.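

Fluoro in place of chloro on this aromatic carbon, para to a large group, gives a measured number rather than a limit: in this assay compound 3 gives 6740 nM. The change reads as an at least 1.4-fold lower number from compound 2 to compound 3 (0.17 log units; that floor lies within the scatter), which is only a floor, and the 4-fluorophenyl group is not separated from the 2,3-dimethylphenyl group, with a 1.4-fold lower number from compound 1 to compound 3 (0.14 log units; within the scatter). Compound 2 itself gives only a limit: the limit of > 10000 nM in this assay, at which 1 of the 3 values shown sits.

As far as these compounds go, the true size of the change from chloro to fluoro stays open, with only a floor available for it. Also open, from the compounds shown here alone, is how an amine or a carboxylic acid on this aromatic carbon would read in this assay, and whether any group here can move the number beyond the scatter from compound 3.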